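A few compounds are considered here, and "the series" means these few. Any claim that something is new, unique, unknown or untested is made for them only; others in the source may bear on it.

Measured compounds:
compound 1 `C#CCN(C)Cc1ccc(NC(=O)CCCC(=O)NO)cc1` — in a functional assay on DU-145 cells (Homo sapiens) for inhibition, read by MTT assay, with a stated time of 48 h (a higher number here means a weaker inhibitor of growth, a lower number a stronger inhibitor of growth), compound 1 gives > 10000 nM, a limit of the assay and not a number.
compound 2 `C#CCN(C)Cc1ccc(NC(=O)CCCCC(=O)NO)cc1` — in this assay compound 2 gives > 10000 nM, again a limit.

Compound 2 therefore stands at the limit of > 10000 nM in this assay, at which 2 of the 2 values shown sit; no numeric value is available for it. Going by the values given here, the one measured step, a step that the two limits leave unreadable from compound 1 to compound 2, is the only step of the same kind and its size cannot be read from the two limits.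

Compound 3 `C#CCN(C)Cc1ccc(NC(=O)CCCCCCC(=O)NO)cc1` differs from compound 2 by 2-(hydroxycarbamoyl)ethyl in place of hydroxycarbamoyl on a saturated chain carbon, four bonds along the chain from a carbonyl carbon. With the only comparable step unreadable, no size or direction of change beyond the scatter can be expected in this assay from the data shown.

Compound 3 is estimated at 15000 nM with a range of 3000 nM to 60000 nM, most probably reported once more as a limit. The expected step is a step that the limit leaves unreadable from compound 2 to compound 3.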

Compound 3, concentration for 50% growth inhibition: 1510 nM
Estimate against measurement, compound 3: 9.9-fold (1.00 log units) above; measured number below the stated range.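

In this assay, going by these compounds alone, lengthening the chain at this position, on a saturated chain carbon, is the first change with a readable effect: 2-(hydroxycarbamoyl)ethyl in place of hydroxycarbamoyl gives an at least 6.6-fold lower number from compound 2 to compound 3 (0.82 log units; beyond the scatter). Counted from the shorter chain, 3-(hydroxycarbamoyl)propyl in place of hydroxycarbamoyl gives an at least 6.6-fold lower number from compound 1 to compound 3 (0.82 log units; beyond the scatter). Compound 3 is the only compound shown with a number, while the step between the two shorter chains remains unreadable and the other values stay at a limit: the limit of > 10000 nM in this assay, at which 2 of the 3 values shown sit.

As far as these compounds go, both readable steps are lower bounds, so their true size remains open, as does whether the change sets in gradually or abruptly along the chain. Also open, from the compounds shown here alone, is whether a longer chain lowers the number further, and whether a carboxylic acid in place of hydroxycarbamoyl retains any of the effect.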